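The compounds below may be only part of what the source reports. "The series", "measured", "known", "first", "only" and "open" are said of these compounds alone.

Three ureas built on one shared core have been measured in a physicochemical assay for solubility, at pH 7.4; a higher number here means a more soluble compound, a lower number a less soluble compound. Compound 1 `Cc1ccc(NC(=O)Nc2cc(C)nc3ccccc23)cc1` gives 1300 nM. Compound 2 `Cc1cc(NC(=O)Nc2ccccc2F)c2ccccc2n1` gives 3800 nM, the highest of the three numbers, while compound 3 `Cc1cc(NC(=O)Nc2ccc(F)cc2F)c2ccccc2n1` gives 3000 nM. The rise a 2.9-fold higher number from compound 1 to compound 2 (0.47 log units; beyond the scatter) lies beyond the scatter, whereas a 1.3-fold lower number from compound 2 to compound 3 (0.10 log units; within the scatter) does not. Compound 4 `Cc1cc(NC(=O)Nc2ccccc2[N+](=O)[O-])c2ccccc2n1` differs from compound 2 by nitro in place of fluoro on an aromatic carbon. Going by the values given here, the one measured step that swaps a small group on that ring, a 1.3-fold lower number from compound 2 to compound 3 (0.10 log units; within the scatter), stayed within the scatter, but it is only a loose guide here, since the group entering is not the same. A step in this assay of at most modest size is therefore expected, more likely downward than upward. The estimate for compound 4 is 2500 nM, between 800 nM and 8000 nM, an expected step of a 1.5-fold lower number from compound 2 to compound 4 (0.18 log units; within the scatter).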

Compound 4, solubility: 200 nM
Compound 4: middle estimate off by 13-fold (1.10 log units), on the high side, outside the stated range (below it).
By their numbers in this assay, from the lowest: compound 4; then compound 1; then compounds 3 and 2 (each within the scatter of the next).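

In this assay nitro in place of fluoro, on an aromatic carbon ortho to a large group, gives a 19-fold lower number from compound 2 to compound 4 (1.28 log units; beyond the scatter) and counts as a large step. The earlier fluoro step on that ring, a 1.3-fold lower number from compound 2 to compound 3 (0.10 log units; within the scatter) and so within the scatter, gave no sign that one swap there could move the number this far. What sits at this position can therefore matter greatly in this series. Whether an amine or a methoxy group in this place would stay close to compound 2 or fall toward compound 4 remains open, and no measurement at hand accounts for the drop.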